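Swapping the Aryl Group on the Saturated Ring Carbon

This account rests on a few compounds, and the source may have more. Where it says the series, first, only, none or still open, it means among the compounds named here.

Compound 1 `COc1ccc(C2OC(c3cc(OC)c(OC)c(OC)c3)=NN2C(C)=O)c(OC)c1` was tested in a functional assay on PC-3 cells (Homo sapiens) for antiproliferative activity, read by MTT assay, tested at 1 uM (on this read-out higher numbers stand for a stronger effect at the one concentration tested and lower numbers for a weaker effect), where compound 1 gives 69.5%. Compound 2 `COc1cc(C(=O)N/N=C/c2cccc(C(F)(F)F)c2)cc(OC)c1OC` in this assay gives 51%. Of the two numbers measured, compound 1 stands highest, and its gap to compound 2 lies beyond the usual scatter. Compound 3 `COc1cc(C2=NN(C(C)=O)C(c3ccc(Cl)c([N+](=O)[O-])c3)O2)cc(OC)c1OC` has not yet been measured in this assay. It differs from compound 1 in one place: 4-chloro-3-nitrophenyl in place of 2,4-dimethoxyphenyl on a saturated ring carbon. For the measured compounds named here, no pair of measured compounds differing in a single place is available, so the size of such a step cannot be read from the data; the shared core is kept and only the group on the saturated ring carbon is exchanged. Nothing measured speaks for a change in either direction. The step of a number 9.5 percentage points lower from compound 1 to compound 3 (within the scatter) is expected to be small, within or only slightly beyond the scatter. For compound 3 the estimate in this assay is 60%, in the range 38% to 80%.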

Compound 3, a percentage reported as inhibition, at one concentration (the size of the read-out at that concentration, not a potency): 43.3%
Compound 3: middle estimate off by 16.7 percentage points, on the high side; the range from low to high includes it.
By their numbers in this assay, from the lowest: compounds 3 and 2 (each within the scatter of the next); then compound 1.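

In this assay, the exchange of 2,4-dimethoxyphenyl for 4-chloro-3-nitrophenyl on the saturated ring carbon gives the first step measured in a single place (a number 26.2 percentage points lower from compound 1 to compound 3 (beyond the scatter)). This position is therefore not indifferent to the group it carries: with the shared core kept, and with the two groups equal in heavy atoms and in hydrogen-bond acceptors by count, the read-out still moves beyond the scatter. No measurement shown here bears on what lies behind this loss of effect.

The exchange removes both methoxy groups and brings in the chlorine and the nitro group at once, and the compounds shown leave open which of these changes carries the step. They also leave open how an unsubstituted phenyl or a pyridine ring on this carbon would read.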